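A few compounds are considered here, and "the series" means these few. Any claim that something is new, unique, unknown or untested is made for them only; others in the source may bear on it.

In a functional assay on DLD-1 cells (Homo sapiens) for cytotoxicity, with a stated time of 48 h (a higher number here means a weaker inhibitor, a lower number a stronger inhibitor), compound 1 `CCCCCOc1ccc2oc(/C=C/[S+](C)[O-])cc(=O)c2c1` gives 6600 nM and compound 3 `CCCCC(=O)Oc1ccc2oc(/C=C/[S+](C)[O-])cc(=O)c2c1` gives 6700 nM. Compound 2 `COc1cccc2oc(/C=C/[S+](C)[O-])cc(=O)c12` gives only a limit, > 10000 nM. The one measured step among these compounds is a 1.0-fold higher number from compound 1 to compound 3 (0.01 log units; within the scatter), so the two stand level in this assay.

Compound 4 `CCCOc1ccc2oc(/C=C/[S+](C)[O-])cc(=O)c2c1` has not yet been measured. It carries propyl in place of butylcarbonyl on an oxygen on an aromatic ring. The measured step bears on this change because a 1.0-fold higher number from compound 1 to compound 3 (0.01 log units; within the scatter) arose from an exchange on that same oxygen, with pentyl giving way to butylcarbonyl. Propyl is a shorter chain than pentyl, and no measured compound shows what shortening that chain does, so the range has to stay wide. No change beyond the scatter is therefore expected, with a slight lean towards a weaker number. The expected step is a 1.2-fold higher number from compound 3 to compound 4 (0.08 log units; within the scatter). The estimated value for compound 4 is 8000 nM, within an expected range of 4000 nM to 15000 nM.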

Compound 4, half-maximal inhibitory concentration: 6200 nM
Beside the measured number, compound 4's estimate is 1.3-fold (0.11 log units) above it; the range from low to high includes it.
By their numbers in this assay, from the lowest: compounds 4, 1 and 3 (each within the scatter of the next). At a limit, above all of these: compound 2.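

In this assay, the oxygen on an aromatic ring has now carried three different groups without the numbers separating them. Propyl in place of butylcarbonyl gives a 1.1-fold lower number from compound 3 to compound 4 (0.03 log units; within the scatter), and hydrogen in place of ethyl on a saturated chain carbon, three bonds along the chain from that oxygen, gives a 1.1-fold lower number from compound 1 to compound 4 (0.03 log units; within the scatter). The earlier step compared only pentyl with butylcarbonyl, whereas these steps show that a propyl chain, with fewer heavy atoms and no carbonyl, also stands level with both groups. Nothing given here explains why these exchanges leave the number in place.

The compounds shown leave open whether any group on this oxygen would move the number beyond the scatter. A much longer chain such as decyl, an amine or a carboxylic acid might do so.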